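Fluoro in place of hydrogen, followed on two cores

A few compounds are considered here, and "the series" means these few. Any claim that something is new, unique, unknown or untested is made for them only; others in the source may bear on it.

Compound 1 `Cn1ccc2c(Oc3ccc(NC(=O)c4nn(-c5ccc(Br)cc5)ccc4=O)cc3)ccnc21` and compound 2 `Cn1ccc2c(Oc3ccc(NC(=O)c4nn(-c5ccc(Br)cc5)ccc4=O)cc3F)ccnc21` share one core; compound 3 `Cc1cc(=O)n(-c2ccccc2OC(F)(F)F)nc1C(=O)Nc1ccc(Oc2ncnc3c2ccn3C)cc1` rests on another, and how the two cores differ is not broken down here. In a functional assay on PC-3 cells (Homo sapiens) for cytotoxicity, read by MTT assay, with a stated time of 72 h (a lower number here means a stronger inhibitor, a higher number a weaker inhibitor), compound 1 gives 23000 nM. Compound 2 reaches only the limit of this assay, > 60000 nM, (the limit of > 60000 nM in this assay, at which 1 of the 3 values shown sits). The change made is fluoro in place of hydrogen on an aromatic carbon, and it produced an at least 2.6-fold higher number from compound 1 to compound 2 (0.41 log units; beyond the scatter). Compound 3 gives 5160 nM in this assay, the lower of the two numbers. Compound 4 `Cc1cc(=O)n(-c2ccccc2OC(F)(F)F)nc1C(=O)Nc1ccc(Oc2ncnc3c2ccn3C)c(F)c1` carries the same change on the core of compound 3: fluoro in place of hydrogen on an aromatic carbon. Compound 4 is expected to give a higher number than compound 3, by about a 2.9-fold higher number from compound 3 to compound 4 (0.46 log units; beyond the scatter), an expectation resting on the size of an at least 2.6-fold higher number from compound 1 to compound 2 (0.41 log units; beyond the scatter). The estimate for compound 4 in this assay is 15000 nM, expected between 5000 nM and 60000 nM.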

Compound 4, half-maximal inhibitory concentration: > 60000 nM
Compound 4 gave a limit, no number; the forecaster's own chance of this, stated with the estimate: 20%; middle value at least 4.0-fold (0.60 log units) away from the limit.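

In this assay, fluoro in place of hydrogen on an aromatic carbon gives a higher number on the second core as well: an at least 11-fold higher number from compound 3 to compound 4 (1.06 log units; beyond the scatter). Compound 4 stands at a limit of the assay, > 60000 nM, and this is not a number. The direction of the change therefore carries over to the second core, but its size on that core is not shown, and the two steps cannot be ranked: the same change on two cores in this assay, an at least 2.6-fold higher number (0.41 log units; beyond the scatter) from compound 1 to compound 2 and an at least 11-fold higher number (1.06 log units; beyond the scatter) from compound 3 to compound 4; the limit leaves it open whether they differ

Going by these compounds, the true size of the change on either core stays open, with compound 2 and compound 4 both at the limit: the limit of > 60000 nM in this assay, at which 2 of the 4 values shown sit. Also open is how chloro, a methyl group or an amine in the same place would read in this assay on either core.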